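Butyl in place of hydroxypropyl on a tellurium aryl oxime

The source may report more compounds than this note shows. Statements on the series, on what has been measured and on what is new or still open speak of the compounds shown alone.

Compound 1, `CCCC[Te]c1ccc(C(C)N)cc1`, in a functional assay, read by spectrophotometry, with a stated time of 30 min; on this read-out lower numbers stand for stronger inhibition and higher numbers for weaker inhibition: 12.1 ug/mL
Compound 2, `CCCC[Te]c1ccc(/C(C)=N/N)cc1`: 5.08 ug/mL
Compound 3, `C/C(=N\O)c1ccc([Te]CCCO)cc1`: 13.1 ug/mL

Compound 3 gives the highest of the three numbers in this assay, but its value and that of compound 1 lie within the scatter of each other, so only compound 2 stands apart from it. Among the compounds with values here, the single measured step, a 2.4-fold lower number from compound 1 to compound 2 (0.38 log units; beyond the scatter), concerns the group on the aromatic carbon and leaves the chain on tellurium untouched.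

Compound 4, `CCCC[Te]c1ccc(/C(C)=N/O)cc1`, differs from compound 3 by methyl in place of hydroxy on a saturated chain carbon, three bonds along the chain from a tellurium atom. Within the data shown here, no measured pair isolates this change: compound 1 and compound 3 differ on the chain and on the aromatic carbon at once, and their two values fall within the scatter of each other; compound 2 and compound 4 share the butyl chain but differ on the aromatic carbon, and no step between them has been measured. With nothing in the data pointing in either direction, the step of a 1.2-fold lower number from compound 3 to compound 4 (0.08 log units; within the scatter) is expected to stay within the scatter. Compound 4 is therefore estimated at 11 ug/mL, with a range from 4.5 ug/mL to 27 ug/mL.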

Compound 4, half-maximal inhibitory concentration: 7.79 ug/mL
Estimate against measurement, compound 4: 1.4-fold (0.15 log units) above, within the range that was stated.
By their numbers in this assay, from the lowest: compounds 2, 4, 1 and 3 (each within the scatter of the next, the first and the last beyond it).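

In this assay, within the data shown here, this is the first pair that isolates the chain on tellurium, and with everything else held, 3-hydroxypropyl to butyl gives a 1.7-fold lower number from compound 3 to compound 4 (0.23 log units; within the scatter), so hydroxy and methyl at this place cannot be told apart on this read-out. Among these compounds, with the butyl chain held, the group on the aromatic carbon can now be read at two further points, a 1.5-fold higher number from compound 2 to compound 4 (0.19 log units; within the scatter), for hydroxy in place of amino on a double-bonded nitrogen, and a 1.6-fold lower number from compound 1 to compound 4 (0.19 log units; within the scatter), for the larger group in place of the smaller one, both within the scatter, so compound 4 cannot be separated from either end of the one step beyond the scatter, a 2.4-fold lower number from compound 1 to compound 2 (0.38 log units; beyond the scatter). No evidence is available that bears on the reason for any of these steps.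

On these data alone, whether an amine or a carboxylic acid at the end of the chain, or a longer chain such as hexyl, would leave the number as little altered remains open. As far as these compounds go, it also remains open whether the exchange of hydroxy for methyl on the chain would read the same with amino rather than hydroxy on the double-bonded nitrogen.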